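The source may hold more compounds than are shown below. What is called first, only, known or untested is meant among the compounds shown, and "the series" means these compounds.

Measured compounds in the series:

Compound 1 `COc1cc(-c2nn(-c3cccc(NC(=O)Nc4cc(C(F)(F)F)cc(C(F)(F)F)c4)c3)cc2-c2ccncc2)ccc1Cl` — 2170 nM
Compound 2 `O=C(Nc1cccc(-n2cc(-c3ccncc3)c(-c3ccc(Cl)c(O)c3)n2)c1)Nc1cc(C(F)(F)F)cc(C(F)(F)F)c1` — 3030 nM
Compound 3 `COc1cc(-c2nn(-c3cccc(NC(=O)Nc4ccc(Cl)c(C(F)(F)F)c4)c3)cc2-c2ccncc2)ccc1Cl` — 2350 nM

All three numbers come from a functional assay on Malme-3M cells (Homo sapiens) for inhibition, read by sulforhodamine B assay, with a stated time of 48 h; a higher number here means a weaker inhibitor of growth, a lower number a stronger inhibitor of growth. Compound 1 and compound 2 are joined by one change, (hydrogen in place of methyl on an oxygen on an aromatic ring), and the step it made was a 1.4-fold higher number from compound 1 to compound 2 (0.14 log units; within the scatter). Compound 3 carries a different core from compound 1; the difference between the two cores is not broken down here. Compound 3 sits close to compound 1 and compound 2 in this assay, and none of the three is separated from the others beyond the scatter.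

Compound 4 `O=C(Nc1cccc(-n2cc(-c3ccncc3)c(-c3ccc(Cl)c(O)c3)n2)c1)Nc1ccc(Cl)c(C(F)(F)F)c1` is not yet measured. It is related to compound 3 by hydrogen in place of methyl on an oxygen on an aromatic ring, the same change made once already from compound 1 to compound 2, at the same place. Given that the earlier step, from compound 1 to compound 2, stayed within the scatter, and that compound 3 gives 2350 nM in this assay, a similarly small step is expected for compound 4, estimated as a 1.4-fold higher number from compound 3 to compound 4 (0.13 log units; within the scatter). Compound 4 is therefore expected to give about 3200 nM in this assay, most plausibly between 1500 nM and 7000 nM.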

Compound 4, concentration for total growth inhibition: 1650 nM
Compound 4: middle estimate off by 1.9-fold (0.29 log units), on the high side; the range from low to high includes it.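

In this assay the change from methoxy to hydroxy on the 4-chloro-3-methoxyphenyl group gave a 1.4-fold lower number from compound 3 to compound 4 (0.15 log units; within the scatter) on the core of compound 3, so the step is small here as well. The two steps are printed with opposite directions, but that difference is not a real one, and on these two cores the change behaves alike within measurement noise: the same change on two cores in this assay, a 1.4-fold higher number (0.14 log units; within the scatter) from compound 1 to compound 2 and a 1.4-fold lower number (0.15 log units; within the scatter) from compound 3 to compound 4, 2.0-fold (0.30 log units) apart, within the scatter of two such steps. Going by these compounds alone, this shows that swapping methoxy for hydroxy carried over between these two cores without a step beyond the scatter, but with only two pairs it does not establish a rule for other cores, and it gives no real direction for the change on either core.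

Still open, as far as these compounds go, is whether a different group at that position, such as an amine or a longer chain on the oxygen, would move the number beyond the scatter. Also open, from the compounds shown here alone, is whether the change stays this small on a core carrying a nitrile or a carboxylic acid in place of the trifluoromethyl.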